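A few compounds are considered here, and "the series" means these few. Any claim that something is new, unique, unknown or untested is made for them only; others in the source may bear on it.

Measured compounds:
compound 1 `COc1ncc(-c2ccc3nc(NC(=O)NCC(=O)N4CCCCC4)nn3c2)cc1NS(=O)(=O)c1ccc(F)cc1` — 2060 nM
compound 2 `COc1ncc(-c2ccc3nc(NC(=O)NCCN4CCCCC4)nn3c2)cc1NS(=O)(=O)c1ccc(F)cc1` — 610 nM
compound 3 `COc1ncc(-c2ccc3nc(NC(=O)NCC(=O)N4CCCC4)nn3c2)cc1NS(=O)(=O)c1ccc(F)cc1` — 2190 nM

In a functional assay on A549 cells (Homo sapiens) for cytotoxicity, read by MTT assay, with a stated time of 72 h (a higher number here means a weaker inhibitor, a lower number a stronger inhibitor), compound 1 gives the second highest of the three numbers; compound 3 sits closest, with a 1.1-fold higher number from compound 1 to compound 3 (0.03 log units; within the scatter), while compound 2 lies furthest, with a 3.4-fold lower number from compound 1 to compound 2 (0.53 log units; beyond the scatter).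

Compound 4 `CNC(=O)Nc1nc2ccc(-c3cnc(OC)c(NS(=O)(=O)c4ccc(F)cc4)c3)cn2n1` is the unmeasured analogue, and it differs from compound 1 as follows: hydrogen in place of (piperidin-1-yl)carbonyl on a saturated chain carbon bound to an amide-type nitrogen

Among the compounds with values here, two measured steps touch the same region. The step from compound 1 to compound 3 was small, within the scatter, and the step from compound 1 to compound 2, which also altered the carbonyl there, was modest. Going by these compounds, removing the group altogether is untested, so only a modest change in either direction is anticipated in this assay.

Compound 4 is therefore estimated at 1500 nM, with a range from 500 nM to 5000 nM.

For compound 4 the expected step is a 1.4-fold lower number from compound 1 to compound 4 (0.14 log units; within the scatter).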

Compound 4, half-maximal inhibitory concentration: 230 nM
For compound 4 the middle estimate is 6.5-fold (0.81 log units) above the measured one, and the stated range ends above it.
By their numbers in this assay, from the lowest: compound 4; then compound 2; then compounds 1 and 3 (each within the scatter of the next).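

In this assay, the plain methylcarbamoyl compound gives a lower number than either carbonyl-bearing analogue (a 9.0-fold lower number from compound 1 to compound 4 (0.95 log units; beyond the scatter); a 9.5-fold lower number from compound 3 to compound 4 (0.98 log units; beyond the scatter)), so neither (piperidin-1-yl)carbonyl nor (pyrrolidin-1-yl)carbonyl is needed on this saturated chain carbon. Within the data shown here, the number also falls on removing (piperidin-1-yl)methyl (a 2.7-fold lower number from compound 2 to compound 4 (0.42 log units; beyond the scatter)), the group that had given the lowest number among the earlier compounds. The compounds shown leave open whether a methyl, a primary amine or a carboxylic acid on this carbon would keep the number this low. Nothing available explains why the number falls when these groups are removed.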